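The source may hold more compounds than are shown below. What is called first, only, known or untested is meant among the compounds shown, and "the series" means these compounds.

Compound 1 `O=C(O)CC/C=C\CO[C@H]1C(OCc2ccc(-c3ccccc3CCO)cc2)CC[C@@H]1N1CCCCCC1` in a functional assay on blood for antagonist activity at thromboxane A2 receptor (Homo sapiens) (on this read-out higher numbers stand for weaker binding and lower numbers for tighter binding), gives 2 nM. Among the compounds with values here, compound 2 `CS(=O)(=O)Nc1ccccc1-c1ccc(COC2CC[C@H](N3CCCCCC3)[C@H]2OC/C=C\CCC(=O)O)cc1` in this assay gives 10 nM; the only change between them is a 5.0-fold higher number from compound 1 to compound 2 (0.70 log units; beyond the scatter), and so compound 2 carries the higher of the two numbers measured so far. Compound 3 `CS(=O)(=O)Nc1cccc(-c2ccc(COC3CC[C@H](N4CCCCCC4)[C@H]3OC/C=C\CCC(=O)O)cc2)c1` is not yet measured; compared with compound 2 it has 3-(methanesulfonamido)phenyl in place of 2-(methanesulfonamido)phenyl on an aromatic carbon. Within the data shown here, no measured step moves a group from one ring position to another, so the one step known, from compound 1 to compound 2, swaps groups rather than positions and bears only loosely on this change. The expectation for compound 3 is therefore a step of a 1.5-fold higher number from compound 2 to compound 3 (0.18 log units; within the scatter) in this assay, with no clear direction beyond the scatter. Compound 3 is estimated at 15 nM, within a range from 4 nM to 60 nM.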

Compound 3, dissociation constant: 12.6 nM
Beside the measured number, compound 3's estimate is 1.2-fold (0.08 log units) above it, and the stated range covers the measured number.
By their numbers in this assay, from the lowest: compound 1; then compounds 2 and 3 (each within the scatter of the next).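

In this assay, shifting the methanesulfonamido group gives a 1.3-fold higher number from compound 2 to compound 3 (0.10 log units; within the scatter), so compound 2 and compound 3 cannot be told apart, and at this site the 2-(methanesulfonamido)phenyl and 3-(methanesulfonamido)phenyl groups read alike in this assay. The step of a 6.3-fold higher number from compound 1 to compound 3 (0.80 log units; beyond the scatter) lies beyond the scatter, as does a 5.0-fold higher number from compound 1 to compound 2 (0.70 log units; beyond the scatter), so compound 1, with its 2-(2-hydroxyethyl)phenyl group, keeps the lowest number against both methanesulfonamido placements shown. Nothing available offers an explanation for either step.

The compounds shown leave open whether the 2-hydroxyethyl group would also give matching numbers if it sat where the methanesulfonamido group sits in compound 3. On these data alone, it also remains open how a carboxylic acid or an amine would read in place of methanesulfonamido on this ring.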